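The source may report more compounds than this note shows. Statements on the series, on what has been measured and on what is new or still open speak of the compounds shown alone.

Compound 1 `COc1cc(N)c(Cl)cc1NC(=O)C1CCN(Cc2ccc(Cl)cc2)CC1` carries a 4-chlorophenyl group on the saturated chain carbon bound to the ring amine nitrogen, and in a functional assay on the whole organism for antagonist activity, with Mus musculus as the target (a higher number here means that more compound is needed for the effect, a lower number that less compound is needed), compound 1 gives 1.2 mg/kg. Compound 2 `CCCN1CCC(C(=O)Nc2cc(Cl)c(N)cc2OC)CC1` has ethyl in that position instead; in this assay compound 2 reaches only the limit of > 10 mg/kg, so no number is known for it. Compound 3 `COc1ccc(CN2CCC(C(=O)Nc3cc(Cl)c(N)cc3OC)CC2)cc1` carries a 4-methoxyphenyl group, and in this assay compound 3 gives 0.9 mg/kg, the lowest of the two numbers shown, though the step of a 1.3-fold lower number from compound 1 to compound 3 (0.12 log units; within the scatter) is within the scatter. The steps of an at least 8.3-fold higher number from compound 1 to compound 2 (0.92 log units; beyond the scatter) and an at least 11-fold lower number from compound 2 to compound 3 (1.04 log units; beyond the scatter) show that an aromatic ring in this position makes a large difference against a plain ethyl chain.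

Compound 4 `COc1cc(N)c(Cl)cc1NC(=O)C1CCN(Cc2ccc(F)cc2)CC1` differs from compound 3 in one place: fluoro in place of methoxy on an aromatic carbon. The step that bears most directly on this is a 1.3-fold lower number from compound 1 to compound 3 (0.12 log units; within the scatter), where swapping chloro for methoxy on the same aromatic carbon made no difference beyond the scatter. Since fluoro is a halogen like chloro and the aromatic ring itself is kept, the expected step of a 1.2-fold higher number from compound 3 to compound 4 (0.09 log units; within the scatter) is none beyond the scatter. Compound 4 is therefore estimated at 1.1 mg/kg, with a likely range from 0.5 mg/kg to 2.5 mg/kg.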

Compound 4, dose for half-maximal effect: 0.6 mg/kg
Compound 4: middle estimate off by 1.8-fold (0.26 log units), on the high side; measured number inside the range.
By their numbers in this assay, from the lowest: compounds 4, 3 and 1 (each within the scatter of the next). At a limit, above all of these: compound 2.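

Fluoro brings one heavy atom and no hydrogen-bond acceptor where methoxy brought two heavy atoms and one acceptor, yet this swap gives a 1.5-fold lower number from compound 3 to compound 4 (0.18 log units; within the scatter), and the halogen swap gives a 2.0-fold lower number from compound 1 to compound 4 (0.30 log units; within the scatter), so among these three groups on this aromatic carbon, this assay draws no distinction beyond the scatter. A third substituted phenyl ring now stands apart from the ethyl of compound 2, with an at least 16-fold lower number from compound 2 to compound 4 (1.22 log units; beyond the scatter), so the large gap between an aromatic ring and a plain ethyl chain holds for chloro, methoxy and fluoro alike. The size of that gap stays open-ended, as compound 2 gives only a limit and not a number: the limit of > 10 mg/kg in this assay, at which 1 of the 4 values shown sits.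

The compounds shown leave open whether any group on this aromatic carbon can move the number beyond the scatter, such as an amine or a carboxylic acid, or how a plain unsubstituted phenyl ring would compare. They also leave open whether the gain over ethyl needs an aromatic ring at all, which a saturated cyclohexyl ring or a longer chain in the same place could help to answer.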